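Swapping the nitro for a methyl on the pendant ring

The source may hold more compounds than are shown below. What is called first, only, known or untested is meant among the compounds shown, and "the series" means these compounds.

Compound 1 `Cc1cccc(-c2ccc(O[C@H]3O[C@H](CO)[C@@H](O)[C@H](O)[C@@H]3O)c(Cl)c2)c1`: 7.1 ug/mL
Compound 2 `N#Cc1cccc(-c2ccc(O[C@H]3O[C@H](CO)[C@@H](O)[C@H](O)[C@@H]3O)c(Cl)c2)c1`: 227 ug/mL
Compound 3 `O=[N+]([O-])c1cccc(-c2ccc(O[C@H]3O[C@H](CO)[C@@H](O)[C@H](O)[C@@H]3O)c(Cl)c2)c1`: 23 ug/mL

In a physicochemical assay for solubility, measured as kinetic solubility, with a stated time of 15 h, at pH 7.4 (a lower number here means a less soluble compound, a higher number a more soluble compound), compound 3 stands second highest of the three, with compound 1 the nearest and compound 2 the furthest from it. Compound 4 `Cc1ccccc1-c1ccc(O[C@H]2O[C@H](CO)[C@@H](O)[C@H](O)[C@@H]2O)c(Cl)c1` differs from compound 3 in one place: 2-methylphenyl in place of 3-nitrophenyl on an aromatic carbon. The step that bears most on this change is the one in the other direction between compound 1, which carries a 3-methylphenyl, and compound 3: a 3.2-fold higher number from compound 1 to compound 3 (0.51 log units; beyond the scatter). Reversing a nitro for a methyl is therefore expected to give a modest step downward in this assay, beyond the scatter. Compound 4 is estimated at 9 ug/mL, within a range of 3 ug/mL to 30 ug/mL, which would mean a 2.6-fold lower number from compound 3 to compound 4 (0.41 log units; beyond the scatter).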

Compound 4, solubility: 135 ug/mL
For compound 4 the middle estimate is 15-fold (1.18 log units) below the measured one; the whole stated range lies below it.
By their numbers in this assay, from the lowest: compound 1; then compound 3; then compounds 4 and 2 (each within the scatter of the next).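

Moving the methyl, from the 3-methylphenyl to the 2-methylphenyl, gives a 19-fold higher number from compound 1 to compound 4 (1.28 log units; beyond the scatter), so in this assay the place of the methyl on this phenyl matters, not only the identity of the group. Against the 3-nitrophenyl there is a 5.9-fold higher number from compound 3 to compound 4 (0.77 log units; beyond the scatter), while against the 3-cyanophenyl there is a 1.7-fold lower number from compound 2 to compound 4 (0.23 log units; within the scatter), so a 2-methylphenyl of carbon only cannot be told apart from the nitrile here. Nothing available gives a reason for these steps. On these data alone, whether the same shift of place holds for the nitrile or the nitro stays open, as does what an amine or a carboxylic acid on this phenyl would give.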